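Benzyl Ether Swap on Two Related Cores in Colon Cells

A few compounds are considered here, and "the series" means these few. Any claim that something is new, unique, unknown or untested is made for them only; others in the source may bear on it.

Compound 1 `Cc1ccc(NC(=S)NC(=O)c2ccc(OCc3cccc(Cl)c3)cc2)cc1-c1nc2ccccc2[nH]1` and compound 2 `Cc1ccc(NC(=S)NC(=O)c2ccc(OCc3ccc(C(F)(F)F)cc3)cc2)cc1-c1nc2ccccc2[nH]1` share a core and differ only in the group on the benzyl ether, while compound 3 `Cc1ccc(NC(=O)NC(=O)c2ccc(OCc3cccc(Cl)c3)cc2)cc1-c1nc2ccccc2[nH]1` rests on a different core. In a functional assay on SW-620 cells (Homo sapiens) for inhibition, read by MTT assay, with a stated time of 48 h (on this read-out higher numbers stand for weaker inhibition and lower numbers for stronger inhibition), compound 1 gives only a limit of the assay, > 100000 nM. In this assay compound 2 gives 72400 nM and compound 3 gives 16000 nM. The change from compound 1 to compound 2 is 4-(trifluoromethyl)phenyl in place of 3-chlorophenyl on a saturated chain carbon bound to an oxygen on an aromatic ring, which gave an at least 1.3-fold lower number from compound 1 to compound 2 (0.14 log units; that floor lies within the scatter). How the core of compound 3 differs from the core of compound 1 is not broken down here. Compound 4 `Cc1ccc(NC(=O)NC(=O)c2ccc(OCc3ccc(C(F)(F)F)cc3)cc2)cc1-c1nc2ccccc2[nH]1`, not yet measured, arises from compound 3 by the same change, (4-(trifluoromethyl)phenyl in place of 3-chlorophenyl on a saturated chain carbon bound to an oxygen on an aromatic ring). A step of a 1.3-fold lower number from compound 3 to compound 4 (0.12 log units; within the scatter) is expected because an at least 1.3-fold lower number from compound 1 to compound 2 (0.14 log units; that floor lies within the scatter) followed the identical change. Compound 4 is estimated at 12000 nM, between 5000 nM and 35000 nM.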

Compound 4, half-maximal inhibitory concentration: 15300 nM
Compound 4: middle estimate off by 1.3-fold (0.11 log units), on the low side; the measured number falls inside the stated range.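

In this assay, 4-(trifluoromethyl)phenyl in place of 3-chlorophenyl gave a 1.0-fold lower number from compound 3 to compound 4 (0.02 log units; within the scatter), so on this core the swap does not move the read-out beyond the usual variation between repeat measurements. Within the data shown here, whether the change carries over from one core to the other in the same way cannot be settled, since only one of the two steps has a full number at both ends: the same change on two cores in this assay, an at least 1.3-fold lower number (0.14 log units; that floor lies within the scatter) from compound 1 to compound 2 and a 1.0-fold lower number (0.02 log units; within the scatter) from compound 3 to compound 4; the limit leaves it open whether they differ. The value of compound 1 is only a limit of the assay, so the true size of the first step is not known: the limit of > 100000 nM in this assay, at which 1 of the 4 values shown sits.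

The compounds shown leave open whether an amine or a carboxylic acid in place of the chlorine or the trifluoromethyl would shift the number beyond the scatter. From the compounds shown here alone, how this change behaves on any further core also remains open.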